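Swapping the Aminophenyl for a Dichlorophenyl Group

The source may report more compounds than this note shows. Statements on the series, on what has been measured and on what is new or still open speak of the compounds shown alone.

Measured in a functional assay on K562 cells (Homo sapiens) for cytotoxicity, read by sulforhodamine B assay, with a stated time of 48 h, tested at 100 uM; a lower number here means a stronger effect, a higher number a weaker effect of the compound at the concentration tested:
compound 1, `COc1ccc(-c2cc(/C=C/C(=O)c3ccc(N)cc3)[nH]n2)cc1`, gives -60%
compound 2, `COc1cc(-c2cc(/C=C/C(=O)c3ccc(N)cc3)[nH]n2)cc(OC)c1OC`, gives -3%

Of these two numbers, compound 2 stands at the higher end: its reading lies well above that of compound 1, and the gap between them is beyond the usual scatter, so compound 2 shows the weaker effect of the pair at the concentration tested. Compound 3, `COc1cc(-c2cc(/C=C/C(=O)c3ccc(Cl)c(Cl)c3)[nH]n2)cc(OC)c1OC`, has not yet been measured in this assay. It differs from compound 2 in one place: 3,4-dichlorophenyl in place of 4-aminophenyl on a carbonyl carbon. Among the compounds with values here, no step between the measured compounds touches this part of the molecule, so there is nothing to lean on for the size of such a change. The expectation is a step from compound 2 to compound 3 of a number 17 percentage points lower from compound 2 to compound 3 (beyond the scatter), toward a stronger effect, though it may also stay within the scatter. Compound 3 is therefore expected to give about -20%, in a range from -70% to 20%.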

Compound 3, a percentage reported as activity, at one concentration (the size of the read-out at that concentration, not a potency): -7%
Beside the measured number, compound 3's estimate is 13 percentage points below it, and the stated range covers the measured number.
By their numbers in this assay, from the lowest: compound 1; then compounds 3 and 2 (each within the scatter of the next).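

In this assay, putting 3,4-dichlorophenyl in place of 4-aminophenyl on the carbonyl carbon gives a number 4 percentage points lower from compound 2 to compound 3 (within the scatter). Within the data shown here, this is the first view of this position, since compound 1 and compound 2 both carry 4-aminophenyl there, and it shows that the reading does not separate the two groups on the core of compound 2, even though the hydrogen-bond donor and acceptor counted on 4-aminophenyl are gone and two chlorine atoms have entered. Nothing measured here explains why the two groups read alike.

Going by these compounds, whether the same swap would also leave the reading unchanged on the core of compound 1, which gives -60%, stays open. So does the reading with a carboxylic acid or a morpholine group on this carbonyl carbon.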